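Replacing the Phenyl Group of Compound 3

The compounds below may be only part of what the source reports. "The series", "measured", "known", "first", "only" and "open" are said of these compounds alone.

- compound 1 `CC(C)c1ccc(Nc2ncnc3ccc(NC(=S)NCc4ccccc4)cc23)cc1`: 12800 nM
- compound 2 `S=C(NCc1ccccc1)Nc1ccc2ncnc(Nc3ccc(-c4ccccc4)cc3)c2c1`: 8400 nM
- compound 3 `S=C(Nc1ccccc1)Nc1ccc2ncnc(Nc3cccc(Br)c3)c2c1`: 10000 nM

In a functional assay on MDA-MB-231 cells (Homo sapiens) for inhibition, read by MTT assay, with a stated time of 48 h (a higher number here means a weaker inhibitor of growth, a lower number a stronger inhibitor of growth), compound 3 gives 10000 nM, a value within the usual scatter of both other measured compounds. The next compound, compound 4 `Fc1ccc(NC(=S)Nc2ccc3ncnc(Nc4cccc(Br)c4)c3c2)cc1Cl`, carries 3-chloro-4-fluorophenyl in place of phenyl on an amide-type nitrogen. Among the measured compounds shown here, no measured step changes this place. For the measured compounds named here, the only measured step, a 1.5-fold lower number from compound 1 to compound 2 (0.18 log units; within the scatter), exchanges isopropyl for phenyl on an aromatic carbon and stays within the scatter. It therefore offers only weak guidance, showing that one substantial change elsewhere in the series left the number in this assay within the scatter. A small step is thus the reasonable expectation, leaning tentatively towards a lower number, and it may not clear the scatter at all. The estimated change is a 1.5-fold lower number from compound 3 to compound 4 (0.19 log units; within the scatter). Compound 4 is expected at 6500 nM, with an estimated range from 2500 nM to 15000 nM.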

Compound 4, concentration for 50% growth inhibition: 300 nM
Compound 4: the middle estimate sits 22-fold (1.34 log units) above what was measured; measured number below the stated range.
By their numbers in this assay, from the lowest: compound 4; then compounds 2, 3 and 1 (each within the scatter of the next).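

In this assay, among the compounds shown here, the exchange of phenyl for 3-chloro-4-fluorophenyl gives a 33-fold lower number from compound 3 to compound 4 (1.52 log units; beyond the scatter) and so lies beyond the scatter, unlike the only earlier step, which concerned a different place. The position on the amide-type nitrogen, whose other neighbour is the thiocarbonyl carbon, therefore responds strongly to substitution, and compound 4 stands apart from compounds 1, 2 and 3. The aromatic ring of carbon stays the same, so the step comes with the added fluorine and chlorine on that ring, though no measurement available here explains it.

The compounds shown leave open whether the chlorine or the fluorine alone would give a step of this size. They also leave open whether a methoxy group or an amine on the same ring would do so.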